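A few compounds are considered here, and "the series" means these few. Any claim that something is new, unique, unknown or untested is made for them only; others in the source may bear on it.

Measured in a functional assay on PC-3 cells (Homo sapiens) for antiproliferative activity, read by MTT assay, with a stated time of 48 h; a higher number here means a weaker inhibitor, a lower number a stronger inhibitor:
Compound 1 `COc1ccc(CN(C(=O)CSc2nc3ccccc3s2)c2cc(OC)c(OC)c(OC)c2)cc1`: 8460 nM
Compound 2 `COc1ccc(CN(C(=O)CSc2nc3ccccc3s2)c2cc(OC)c(OC)c(OC)c2)cc1O`: 2110 nM
Compound 3 `COc1ccc(CN(C(=O)CSc2nc3ccccc3s2)c2cc(OC)c(OC)c(OC)c2)cc1OC`: > 80000 nM

Compound 3 stands at the limit of > 80000 nM in this assay, at which 1 of the 3 values shown sits, so its value is a limit and not a number. Compound 4 `COc1ccc(CN(C(=O)CSc2nc3ccccc3s2)c2cc(OC)c(OC)c(OC)c2)cc1C(F)(F)F` has trifluoromethyl in place of methoxy on an aromatic carbon, ortho to a methoxy group (trifluoromethyl in place of methoxy on an aromatic carbon). That same carbon carries hydrogen in compound 1, hydroxy in compound 2 and methoxy in compound 3. Changes there were clearly felt: a 4.0-fold lower number from compound 1 to compound 2 (0.60 log units; beyond the scatter), an at least 9.4-fold higher number from compound 1 to compound 3 (0.97 log units; beyond the scatter) and an at least 37-fold higher number from compound 2 to compound 3 (1.57 log units; beyond the scatter). Trifluoromethyl is untested at this carbon, so the size of the step is uncertain. With compound 1 at 8460 nM, a result closer to that number is expected for compound 4. The expected result is an at least 4.0-fold lower number from compound 3 to compound 4 (0.60 log units; beyond the scatter). Compound 4 is estimated at 20000 nM, with an expected range of 5000 nM to 80000 nM.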

Compound 4, half-maximal inhibitory concentration: > 80000 nM
Compound 4 gave a limit, no number (the forecaster's own chance of this, stated with the estimate: 30%); middle value at least 4.0-fold (0.60 log units) away from the limit.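

In this assay, trifluoromethyl at this carbon gives an at least 9.4-fold higher number from compound 1 to compound 4 (0.97 log units; beyond the scatter) and an at least 37-fold higher number from compound 2 to compound 4 (1.57 log units; beyond the scatter). Methoxy is therefore no longer the only group here that leaves no measurable number, while hydrogen and hydroxy still give one. The values of compound 3 and compound 4 are both limits, so the step between them cannot be read and the two groups cannot be ranked: the limit of > 80000 nM in this assay, at which 2 of the 4 values shown sit.

From the compounds shown here alone, whether an amine or a single fluorine atom at this carbon would give a measurable number stays open.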